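This account rests on a few compounds, and the source may have more. Where it says the series, first, only, none or still open, it means among the compounds named here.

Measured so far, in a functional assay on CHO cells for agonist activity at Free fatty acid receptor 1 (Rattus norvegicus), read by calcium flux; a lower number here means that less compound is needed, a higher number that more compound is needed for the effect:
compound 1, `Cc1cccc(C)c1-c1cccc(COc2ccc(CC(C)C(=O)O)cn2)c1` — 2100 nM.
compound 2, `COC(Cc1ccc(OCc2cccc(-c3c(C)cccc3C)c2)nc1)C(=O)O` — > 10000 nM.
compound 3, `CCOC(CC(=O)O)c1ccc(OCc2cccc(-c3c(C)cccc3C)c2)nc1` — 130 nM.

The entry of compound 2 is a limit of this assay and not a number (the limit of > 10000 nM in this assay, at which 1 of the 3 values shown sits). Compound 3 holds the lowest number of the two that are numbers; the nearest, compound 1, gives a number higher by a 16-fold lower number from compound 1 to compound 3 (1.21 log units; beyond the scatter). The step from compound 2 to compound 3 is an at least 76-fold lower number from compound 2 to compound 3 (1.88 log units; beyond the scatter), and that from compound 1 to compound 2 is an at least 4.7-fold higher number from compound 1 to compound 2 (0.67 log units; beyond the scatter).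

Compound 4, `CCOC(CC(=O)O)c1ccc(OCc2ccccc2)nc1`, differs from compound 3 at a different place: hydrogen in place of 2,6-dimethylphenyl on an aromatic carbon. None of the three measured steps touches this part of the molecule; all of them change the acid-bearing side chain, which compound 4 keeps unchanged from compound 3. The 2,6-dimethylphenyl group is present in every measured compound, so the measurements give no direct gauge of its removal. Its loss is expected to raise the number in this assay, by a step of about a 38-fold higher number from compound 3 to compound 4 (1.59 log units; beyond the scatter). The estimate for compound 4 is therefore 5000 nM, with a range from 1500 nM to 20000 nM, and a fair chance that the assay reports only a limit.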

Compound 4, half-maximal effective concentration: 760 nM
Beside the measured number, compound 4's estimate is 6.6-fold (0.82 log units) above it; measured number outside the range, below it.
By their numbers in this assay, from the lowest: compound 3; then compound 4; then compound 1. At a limit, above all of these: compound 2.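

In this assay, removing the 2,6-dimethylphenyl group, with its 8 heavy atoms and its six-membered aromatic ring of carbon only, gives a 5.8-fold higher number from compound 3 to compound 4 (0.77 log units; beyond the scatter), a modest step. This is the only change shown away from the acid-bearing side chain, and it shows that the number also depends on what sits on this aromatic carbon, although the group is not needed for a measurable response: compound 4, which carries hydrogen there, still gives 760 nM. Nothing in the data shown accounts for the size of this step.

On these data alone, it remains open whether a different group on this aromatic carbon, such as a methyl, a methoxy or an unsubstituted phenyl, would give a number closer to that of compound 3 or to that of compound 4. The change is also shown only with the 2-carboxy-1-ethoxyethyl side chain, so the compounds shown leave open whether replacing the 2,6-dimethylphenyl group with hydrogen would give a step of similar size with the 2-carboxypropyl side chain of compound 1.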